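Swapping a Whole Ring Group

The compounds below may be only part of what the source reports. "The series", "measured", "known", "first", "only" and "open" are said of these compounds alone.

In a functional assay on HCT-116 cells (Homo sapiens) for inhibition (on this read-out higher numbers stand for weaker inhibition and lower numbers for stronger inhibition), three compounds share a core and differ in one small group: compound 1 `CCNC(=O)c1noc(-c2cc(C(C)C)c(O)cc2O)c1-c1cc(CN(C)C)no1` gives 92 nM and compound 2 `CCNC(=O)c1noc(-c2cc(C(C)C)c(O)cc2O)c1-c1cc(C(N)=O)no1` gives 79 nM while compound 3 `CCNC(=O)c1noc(-c2cc(C(C)C)c(O)cc2O)c1-c1cc(C(=O)NC)no1` gives 124 nM on the same scale. Compound 3 therefore stands level with the other two (the steps are a 1.3-fold higher number from compound 1 to compound 3 (0.13 log units; within the scatter) and a 1.6-fold higher number from compound 2 to compound 3 (0.20 log units; within the scatter) and both lie within the scatter).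

Compound 4 `CCNC(=O)c1noc(-c2cc(C(C)C)c(O)cc2O)c1-c1cnn(C)c1` changes more: 1-methyl-1H-pyrazol-4-yl replaces the entire 3-(methylcarbamoyl)-1,2-oxazol-5-yl group (1-methyl-1H-pyrazol-4-yl in place of 3-(methylcarbamoyl)-1,2-oxazol-5-yl on an aromatic carbon).

Within the data shown here, no measured step makes this swap, so the evidence is indirect. The closest guides are the changes on that group, such as a 1.2-fold lower number from compound 1 to compound 2 (0.07 log units; within the scatter) and the two steps to compound 3, and none of them moved the number beyond the scatter. The expected result is therefore no clear shift in either direction, which means an estimated step of a 1.0-fold higher number from compound 3 to compound 4 (0.02 log units; within the scatter) and a wide margin for the larger change. Compound 4 is estimated at 130 nM (expected range 45 nM to 400 nM).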

Compound 4, half-maximal inhibitory concentration: 41 nM
Estimate against measurement, compound 4: 3.2-fold (0.50 log units) above; the whole stated range lies above it.
By their numbers in this assay, from the lowest: compounds 4, 2, 1 and 3 (each within the scatter of the next, the first and the last beyond it).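

Changes made on the 3-substituted 1,2-oxazol-5-yl group never moved the number beyond the scatter in this assay, but replacing that whole group with 1-methyl-1H-pyrazol-4-yl does so against two of the three earlier compounds (a 3.0-fold lower number from compound 3 to compound 4 (0.48 log units; beyond the scatter); a 2.2-fold lower number from compound 1 to compound 4 (0.35 log units; beyond the scatter)), while compound 4 stays level with compound 2 (a 1.9-fold lower number from compound 2 to compound 4 (0.28 log units; within the scatter)). This position on the shared core therefore keeps a number at this level without any of the carbamoyl, methylcarbamoyl or (dimethylamino)methyl groups, and the ring group as a whole matters more here than those small groups did. Nothing shown here gives a reason for these steps.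

Still open, from the compounds shown here alone, is how a 1H-pyrazol-4-yl group without the methyl, a 1-ethyl-1H-pyrazol-4-yl group or a phenyl ring would read at this place. Such groups would help separate the contribution of the methyl from that of the ring.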